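Ring amine returns to the amide of compound 3

A few compounds are considered here, and "the series" means these few. Any claim that something is new, unique, unknown or untested is made for them only; others in the source may bear on it.

Compound 3 `COc1ccc(CNC(=O)c2c(N)sc(-c3ccc(Cl)cc3)c2-c2ccc(Cl)cc2)cc1` gives 18200 nM in a functional assay on A549 cells (Homo sapiens) for inhibition, read by sulforhodamine B assay, with a stated time of 72 h (a lower number here means a stronger inhibitor, a higher number a weaker inhibitor), the highest of the three numbers; compound 2 `Nc1sc(-c2ccc(Cl)cc2)c(-c2ccc(Cl)cc2)c1C(=O)NCc1ccccc1` gives 16300 nM and lies within the scatter of it, while compound 1 `Nc1sc(-c2ccc(Cl)cc2)c(-c2ccc(Cl)cc2)c1C(=O)N1CCCC1` gives 890 nM, well separated. Compound 4 `CC1CN(C(=O)c2c(N)sc(-c3ccc(Cl)cc3)c2-c2ccc(Cl)cc2)CCN1` differs from compound 3 by 3-methylpiperazin-1-yl in place of (4-methoxybenzyl)amino on a carbonyl carbon. Going by the values given here, the steps that bear on this exchanged a ring amine for a benzylic amine on the carbonyl carbon: an 18-fold higher number from compound 1 to compound 2 (1.26 log units; beyond the scatter) and a 20-fold higher number from compound 1 to compound 3 (1.31 log units; beyond the scatter), both large. The step of a 1.1-fold higher number from compound 2 to compound 3 (0.05 log units; within the scatter) shows the methoxy group alone makes no difference beyond the scatter. Given the large step of a 20-fold higher number from compound 1 to compound 3 (1.31 log units; beyond the scatter) in compound 1, compound 4 is expected to move back toward it, with a 12-fold lower number from compound 3 to compound 4 (1.08 log units; beyond the scatter). Compound 4 is estimated at 1500 nM, within 400 nM to 6000 nM.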

Compound 4, half-maximal inhibitory concentration: 4930 nM
Compound 4: middle estimate off by 3.3-fold (0.52 log units), on the low side; low and high end bracket the measured number.
By their numbers in this assay, from the lowest: compound 1; then compound 4; then compounds 2 and 3 (each within the scatter of the next).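

In this assay the ring amine on the carbonyl carbon gives back only part of the loss seen with the benzylic amides, with a 3.7-fold lower number from compound 3 to compound 4 (0.57 log units; beyond the scatter) and a 3.3-fold lower number from compound 2 to compound 4 (0.52 log units; beyond the scatter) on one side and a 5.5-fold higher number from compound 1 to compound 4 (0.74 log units; beyond the scatter) on the other. A ring amine as such therefore does not fix the number here: 3-methylpiperazin-1-yl and pyrrolidin-1-yl are told apart at this position. Nothing given explains that gap. Going by these compounds, whether a morpholine, a piperidine or a piperazine without the methyl group would come closer to compound 1 stays open.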